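Hydroxylamine on the aminopyrimidinone: tolerance in liver cells

This account rests on a few compounds, and the source may have more. Where it says the series, first, only, none or still open, it means among the compounds named here.

Working notes on a small deoxynucleoside series, with three compounds so far. Compound 1 `O=c1nc(NO)ccn1[C@@H]1C[C@@H](O)[C@H](CO)O1` carries a hydroxyamino group; in an ADME assay on HepG2 cells (Homo sapiens) for cytotoxicity, read by MTT assay, with a stated time of 3 days (a higher number here means that more compound is tolerated, a lower number that less compound is tolerated), compound 1 gives 545000 nM. Compound 2 `Cc1cn([C@@H]2C[C@@H](O)[C@H](CO)O2)c(=O)nc1N` carries an amino group instead, with a methyl on the ring. In this assay compound 2 reaches only the limit of the method, > 2000000 nM, so no number is known for it. Among the measured compounds shown here, compound 2 therefore stands at the edge of what the method can report, as the evidence states (the limit of > 2000000 nM in this assay, at which 1 of the 2 values shown sits), and no step between measured compounds exists for comparison.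

Compound 3 `Cc1cn([C@@H]2C[C@@H](O)[C@H](CO)O2)c(=O)nc1NO` is to be measured in this assay. It differs from compound 2 by hydroxy in place of hydrogen on a nitrogen on an aromatic ring. Compound 1, which also carries the hydroxyamino group, gives 545000 nM, so a drop toward less tolerance is expected for compound 3, beyond the scatter. The step of an at least 2.5-fold lower number from compound 2 to compound 3 (0.39 log units; beyond the scatter) is an estimate; compound 3 is expected at 800000 nM, in the range 300000 nM to 2000000 nM.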

Compound 3, half-maximal cytotoxic concentration: 490000 nM
For compound 3 the middle estimate is 1.6-fold (0.21 log units) above the measured one, within the range that was stated.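

In this assay, hydroxy in place of hydrogen on a nitrogen on an aromatic ring gives the first readable effect at this position, an at least 4.0-fold lower number from compound 2 to compound 3 (0.61 log units; beyond the scatter), so amino to hydroxyamino reduces tolerance on the methyl-bearing core. On these data alone, this step has only a lower bound, and its full size remains unknown: the limit of > 2000000 nM in this assay, at which 1 of the 3 values shown sits. With the hydroxyamino group in place, the methyl on the aromatic carbon leaves tolerance within the scatter, a 1.1-fold lower number from compound 1 to compound 3 (0.05 log units; within the scatter).

As far as these compounds go, whether the amino group also reaches the limit without the methyl remains open, so the step is established only on the methyl-bearing core. Also open, from the compounds shown here alone, is how a methoxy group on the same nitrogen, in place of the hydroxy, would read in this assay.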